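From piperazin-1-yl to 4-carbamoylpiperidin-1-yl in cell tolerance

The source may hold more compounds than are shown below. What is called first, only, known or untested is meant among the compounds shown, and "the series" means these compounds.

Compound 1 `CCCNC(=O)c1cc2sccc2n1Cc1ccc(OC)cc1`: > 100000 nM (a limit)
Compound 2 `CCN(CC)C(=O)c1cc2sccc2n1Cc1ccc(OC)cc1`: > 100000 nM (a limit)
Compound 3 `COc1ccc(Cn2c(C(=O)N3CCNCC3)cc3sccc32)cc1`: > 100000 nM (a limit)

These three compounds share one core and differ only in the group on a carbonyl carbon. In an ADME assay on HEK-293T cells (Homo sapiens) for cytotoxicity, read by luminescence, with a stated time of 24 h (a lower number here means that less compound is tolerated, a higher number that more compound is tolerated), compound 3 gives > 100000 nM. That value is a limit of the assay and not a number. The same holds across the series: the limit of > 100000 nM in this assay, at which 3 of the 3 values shown sit. Compound 3 therefore has no exact place among its neighbours.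

Compound 4 `COc1ccc(Cn2c(C(=O)N3CCC(C(N)=O)CC3)cc3sccc32)cc1` keeps the core and changes that one group: 4-carbamoylpiperidin-1-yl in place of piperazin-1-yl on a carbonyl carbon. Put simply, 4-carbamoylpiperidin-1-yl stands in place of piperazin-1-yl on a carbonyl carbon.

Two measured changes touch the same place: a step that the two limits leave unreadable from compound 1 to compound 3, and a step that the two limits leave unreadable from compound 2 to compound 3. The third, a step that the two limits leave unreadable from compound 1 to compound 2, has no readable size either. So no change at this carbonyl carbon has yet produced a number. The expectation starts from compound 3 at > 100000 nM, and no step beyond the usual scatter is expected, in either direction. The expected change is a number no higher from compound 3 to compound 4 (the limit leaves the size open). Most likely the assay will again report only a limit. The estimate for compound 4 is 100000 nM, with an expected range from 50000 nM to 200000 nM.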

Compound 4, half-maximal cytotoxic concentration: > 100000 nM
Compound 4 was reported as a limit (the forecaster's own chance of this, stated with the estimate: 85%); the middle value sits exactly at the limit.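

In this assay compound 4 gives > 100000 nM, which is a limit and not a number. For the compounds shown here, no step from compound 1, compound 2 or compound 3 to compound 4 can be read, and the series stays as it was: the limit of > 100000 nM in this assay, at which 4 of the 4 values shown sit. The compounds shown leave open what concentration each needs to harm the cells, and whether any group on the carbonyl carbon changes it.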